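Replacing the hexyl of compound 2 with an aromatic group

The compounds below may be only part of what the source reports. "The series", "measured", "known", "first", "only" and "open" are said of these compounds alone.

In an ADME assay on Vero cells (Chlorocebus sabaeus) for cytotoxicity, with a stated time of 72 h (on this read-out higher numbers stand for lower toxicity in this test and lower numbers for higher toxicity in this test), compound 1 `CN1CCN(c2ccc(C(=O)C3CC3c3ccc(Cl)cc3)cc2)CC1` gives 82.1 ug/mL, compound 2 `CCCCCCCNc1ccc(C(=O)C2CC2c2ccc(Cl)cc2)cc1` gives 398 ug/mL and compound 3 `CCCCCCCC/C=C\CCCCCCCCNc1ccc(C(=O)C2CC2c2ccc(Cl)cc2)cc1` gives 393 ug/mL. Compound 2 therefore shares the top of the three numbers with compound 3, and both lie clearly above compound 1. The next structure is compound 4 `COc1ccc(CNc2ccc(C(=O)C3CC3c3ccc(Cl)cc3)cc2)cc1OC`, which differs from compound 2 as follows: 3,4-dimethoxyphenyl in place of hexyl on a saturated chain carbon bound to a nitrogen on an aromatic ring. Going by the values given here, two measured steps bear on this change. The first, heptylamino in place of 4-methylpiperazin-1-yl, is a 4.8-fold higher number from compound 1 to compound 2 (0.69 log units; beyond the scatter) and shows that the group on this nitrogen side of the molecule can move the number. The second, undec-2-en-1-yl in place of hydrogen on the chain, is a 1.0-fold lower number from compound 2 to compound 3 (0.01 log units; within the scatter) and shows a large addition to the chain with no shift beyond the scatter. Among the compounds with values here, no measured compound carries an aromatic ring on this chain, so the evidence is indirect. A small downward lean is expected, and no step beyond the scatter. The estimated change is a 1.4-fold lower number from compound 2 to compound 4 (0.15 log units; within the scatter). Compound 4 is estimated at 280 ug/mL, with an expected range of 110 ug/mL to 520 ug/mL.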

Compound 4, half-maximal cytotoxic concentration: 422 ug/mL
Compound 4: middle estimate off by 1.5-fold (0.18 log units), on the low side; the measured number falls inside the stated range.
By their numbers in this assay, from the lowest: compound 1; then compounds 3, 2 and 4 (each within the scatter of the next).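

In this assay, 3,4-dimethoxyphenyl in place of hexyl on a saturated chain carbon bound to a nitrogen on an aromatic ring gives a 1.1-fold higher number from compound 2 to compound 4 (0.03 log units; within the scatter), a step within the scatter. Until now, only open chains had been seen on this nitrogen; this position now also tolerates an aromatic ring of carbon only, with its two methoxy groups, without a change in the number beyond the scatter. No available evidence bears on why the number holds across this change.

Still open, as far as these compounds go, is whether a plain phenyl, or a ring carrying a carboxylic acid or an amine in place of the methoxy groups, would stay within the scatter of compound 2. Also open, from the compounds shown here alone, is how a longer link between this nitrogen and the ring, such as an ethylene chain, would read.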